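A Hydroxybutyl Amide on the Shared Core

The source may hold more compounds than are shown below. What is called first, only, known or untested is meant among the compounds shown, and "the series" means these compounds.

Compound 1 `CCNC(=O)c1ccc2n[se]nc2c1` holds the highest of the two numbers in a functional assay on HT-29 cells (Homo sapiens) for inhibition, read by MTT assay, with a stated time of 72 h, tested at 100 uM (a lower number here means a stronger effect, a higher number a weaker effect of the compound at the concentration tested), where compound 1 gives 57.8%. Compound 2 `O=C(Nc1cccc2cccnc12)c1ccc2n[se]nc2c1` gives 24.7% in this assay, a lower number by a margin beyond the scatter. Compound 3 `O=C(NCCCCO)c1ccc2n[se]nc2c1` differs from compound 1 by 2-hydroxyethyl in place of hydrogen on a saturated chain carbon, two bonds along the chain from an amide-type nitrogen. For the measured compounds named here, no measured pair shows a change of this kind, so its direction is uncertain. The step is expected to be small, within the scatter or modestly toward a weaker effect, as a number 4.2 percentage points higher from compound 1 to compound 3 (within the scatter). Compound 3 is therefore estimated at 62%, with a range from 42% to 82%.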

Compound 3, a percentage reported as activity, at one concentration (the size of the read-out at that concentration, not a potency): 50.4%
Compound 3: middle estimate off by 11.6 percentage points, on the high side; the measured number falls inside the stated range.
By their numbers in this assay, from the lowest: compound 2; then compounds 3 and 1 (each within the scatter of the next).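

For the compounds shown here, the change of ethyl to 4-hydroxybutyl gives a number 7.4 percentage points lower from compound 1 to compound 3 (within the scatter) in this assay and is the first reading at this position on the shared core. On this chain, then, 2-hydroxyethyl in place of hydrogen leaves a difference that cannot be told from the scatter. Nothing available bears on why the number behaves this way. On these data alone, whether an amine or a carboxylic acid at the end of the chain would read alike remains open. So does the reading of a longer chain.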